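Tert-butyl for Neopentyl on the Core of Compound 3

The source may hold more compounds than are shown below. What is called first, only, known or untested is meant among the compounds shown, and "the series" means these compounds.

In a functional assay on a cell-free system (plasma, Homo sapiens), with a stated time of 3 min (a higher number here means a weaker inhibitor, a lower number a stronger inhibitor), three compounds have been measured:
Compound 1 `CC(C)(C)[C@@H](O)C(=O)N1C[C@@H]2C[C@@H]2[C@H]1C(=O)NCc1cc(Cl)ccc1-n1cnnn1` gives 570 nM.
Compound 2 `CC(C)(C)C[C@@H](O)C(=O)N1C[C@@H]2C[C@@H]2[C@H]1C(=O)NCc1cc(Cl)ccc1-n1cnnn1` gives 910 nM.
Compound 3 `CC(C)(C)C[C@@H](O)C(=O)N1[C@@H]2C[C@@H]2C[C@H]1C(=O)NCc1cc(Cl)ccc1-n1cnnn1` gives 520 nM.

Compound 1 and compound 2 share one core and differ only in the side chain: tert-butyl in place of neopentyl on a saturated chain carbon bound to a carbonyl carbon and an oxygen on a saturated carbon. This change gave a 1.6-fold lower number from compound 2 to compound 1 (0.20 log units; within the scatter), so the two numbers cannot be told apart with confidence. Compound 3 carries the neopentyl side chain on a core built from the same atoms as the core of compound 2, joined differently; the difference between the two cores is not broken down here. The value of compound 3 sits close to those of compound 1 and compound 2, all three within the usual scatter of one another.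

Compound 4 `CC(C)(C)[C@@H](O)C(=O)N1[C@@H]2C[C@@H]2C[C@H]1C(=O)NCc1cc(Cl)ccc1-n1cnnn1`, not yet measured, is made from compound 3 by the same change: tert-butyl in place of neopentyl on a saturated chain carbon bound to a carbonyl carbon and an oxygen on a saturated carbon. Because that change gave a 1.6-fold lower number from compound 2 to compound 1 (0.20 log units; within the scatter) on the other core, a similarly small step is expected in this assay: a 1.6-fold lower number from compound 3 to compound 4 (0.20 log units; within the scatter). Compound 4 is therefore estimated at 330 nM, most likely between 150 nM and 700 nM.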

Compound 4, half-maximal inhibitory concentration: 1100 nM
Compound 4: middle estimate off by 3.3-fold (0.52 log units), on the low side; the whole stated range lies below it.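

In this assay, putting tert-butyl in place of neopentyl on the core of compound 3 gave a 2.1-fold higher number from compound 3 to compound 4 (0.33 log units; beyond the scatter), a modest rise in the number, which here means a weaker inhibitor. The same change on the other core did not give a step of matching size, and the two results differ by more than repeat measurements would explain: the same change on two cores in this assay, a 1.6-fold lower number (0.20 log units; within the scatter) from compound 2 to compound 1 and a 2.1-fold higher number (0.33 log units; beyond the scatter) from compound 3 to compound 4, 3.4-fold (0.53 log units) apart, beyond the scatter of two such steps. This shows that, for these two pairs, the result of the change on one core could not be carried over to the other; it does not show why, and two pairs cannot predict the outcome on a third core, especially as the step on the first core is itself within the scatter.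

The compounds shown leave open how other groups would behave in the same place on either core, such as isopropyl, a longer chain or an amine. They also leave open whether the gap between the two steps would hold in a different kind of test.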